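From dipentylamino to (dibutylamino)methyl on the side chain

The source may hold more compounds than are shown below. What is called first, only, known or untested is meant among the compounds shown, and "the series" means these compounds.

Within the data shown here, in a functional assay (aorta) with Rattus norvegicus as the target (a lower number here means a stronger inhibitor, a higher number a weaker inhibitor), compound 2 `CCCCCN(CCCCC)CCCOc1ccc(S(=O)(=O)c2c(C(C)C)cn3ccccc23)cc1` gives 89.6 nM, the higher of the two numbers measured so far, which makes it the weaker inhibitor of the pair. The other measured compound, compound 1 `CC(C)c1cn2ccccc2c1S(=O)(=O)c1ccc(OCCCNCc2ccccc2)cc1`, gives 22.8 nM. Compound 3 `CCCCN(CCCC)CCCCOc1ccc(S(=O)(=O)c2c(C(C)C)cn3ccccc23)cc1` keeps the shared core and alters only the amine end of the side chain: (dibutylamino)methyl in place of dipentylamino on a saturated chain carbon, three bonds along the chain from an oxygen on an aromatic ring. Among the measured compounds shown here, one measured step bears on this, and only indirectly: a 3.9-fold higher number from compound 1 to compound 2 (0.59 log units; beyond the scatter), a modest change made at the same place when dipentylamino replaced benzylamino. That step involved losing a ring, whereas neither group here has one, and the two groups are closely similar in size. Only a small change in this assay is therefore expected, with no firm direction and probably nothing beyond the scatter. The expected step is a 1.3-fold lower number from compound 2 to compound 3 (0.11 log units; within the scatter). The estimate for compound 3 is 70 nM, within an expected range of 28 nM to 175 nM.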

Compound 3, half-maximal inhibitory concentration: 20.2 nM
The estimate for compound 3 lay 3.5-fold (0.54 log units) above the measured number; the whole stated range lies above it.
By their numbers in this assay, from the lowest: compounds 3 and 1 (each within the scatter of the next); then compound 2.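

In this assay, the change to (dibutylamino)methyl gives a 4.4-fold lower number from compound 2 to compound 3 (0.65 log units; beyond the scatter), so this end of the side chain responds to a swap between two ring-free groups, and the effect here is not limited to the loss of a ring. The same difference also reads as (dipentylamino)methyl to 2-(dibutylamino)ethyl, which shows that the chain and the groups on the nitrogen change together, and a benzylamino ring proves dispensable at this position, as a 1.1-fold lower number from compound 1 to compound 3 (0.05 log units; within the scatter) places the ring-free and ring-bearing groups on a par. No available evidence explains the size of either step.

The compounds shown leave the effects of chain length and of the groups on the nitrogen unseparated. From the compounds shown here alone, a dibutylamino group on the shorter chain would help to separate them, and how a piperidine ring would fare at this position remains open.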